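A few compounds are considered here, and "the series" means these few. Any claim that something is new, unique, unknown or untested is made for them only; others in the source may bear on it.

Working notes on the series. Compound 1 (`COc1cnc(C[S+]([O-])c2nc3cc(OC(F)F)ccc3[nH]2)cc1OC`) reads > 200 h in an ADME assay for pharmacokinetics, at pH 7.4 (on this read-out higher numbers stand for a longer-lived compound and lower numbers for a shorter-lived compound), and that reading is a limit of the assay, not a number. Compound 2 (`COc1cnc(C[S+]([O-])c2nc3cc(OC(F)(F)C(F)F)ccc3[nH]2)cc1OC`) gives 140 h and holds the higher of the two actual numbers, while compound 3 (`COc1cnc(C[S+]([O-])c2nc3cc(OC(F)(F)C(F)F)ccc3[nH]2)c(C)c1OC`) gives 43 h in the same read-out. From compound 2 to compound 4 (`COc1cc(C[S+]([O-])c2nc3cc(OC(F)(F)C(F)F)ccc3[nH]2)ncc1C`) the change is methyl in place of methoxy on an aromatic carbon. On the saturated chain there is an at least 1.4-fold lower number from compound 1 to compound 2 (0.15 log units; that floor lies within the scatter) and this starts from a limit, so it offers little guidance here. Within the data shown here, the nearer guide is a 3.3-fold lower number from compound 2 to compound 3 (0.51 log units; beyond the scatter) with methyl placed on an aromatic carbon, although no measured step removes a methoxy, so a modest fall of similar or smaller size is expected. The expected change is a 2.0-fold lower number from compound 2 to compound 4 (0.30 log units; within the scatter) in this assay on this estimate. For compound 4 the estimated value is 70 h (expected range 30 h to 150 h).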

Compound 4, half-life: 18 h
Estimate against measurement, compound 4: 3.9-fold (0.59 log units) above; measured number outside the range, below it.
By their numbers in this assay, from the lowest: compound 4; then compound 3; then compound 2. At a limit, above all of these: compound 1.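

In this assay methyl in place of methoxy on an aromatic carbon gives a 7.8-fold lower number from compound 2 to compound 4 (0.89 log units; beyond the scatter) and so shows that this position, para to a large group and two atoms from the ring nitrogen, is sensitive to this change. The only other single change shown on this ring, methyl in place of hydrogen, gives a 3.3-fold lower number from compound 2 to compound 3 (0.51 log units; beyond the scatter) and so compound 4 adds a second case, this time with a methoxy leaving, in which the number falls. Nothing shown gives a cause for this fall.

The two compounds cannot separate what is lost with the methoxy from what is gained with the methyl. As far as these compounds go, how an amine, a chlorine atom or a longer alkoxy chain would read at this position stays open.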